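A benzofuran in place of a furan

The compounds below may be only part of what the source reports. "The series", "measured", "known", "first", "only" and "open" are said of these compounds alone.

Compound 1 (`O=c1[nH]cnc2c1c(-c1ccccc1)cn2[C@@H]1O[C@H](CO)[C@@H](O)[C@H]1O`): > 100000 nM as a limit
Compound 2 (`Nc1nc(N)c2c(-c3ccco3)cn([C@@H]3O[C@H](CO)[C@@H](O)[C@H]3O)c2n1`): > 20000 nM as a limit

In a functional assay on CCRF-CEM cells (Homo sapiens), read by MTT assay, with a stated time of 72 h (on this read-out higher numbers stand for weaker inhibition and lower numbers for stronger inhibition), compound 2 stands at > 20000 nM as a limit and gives no number. Compound 1 likewise shows only a limit at > 100000 nM and no number. Compound 3 (`Nc1nc(N)c2c(-c3cc4ccccc4o3)cn([C@@H]3O[C@H](CO)[C@@H](O)[C@H]3O)c2n1`) differs from compound 2 by 1-benzofuran-2-yl in place of furan-2-yl on an aromatic carbon with 1-benzofuran-2-yl in place of furan-2-yl on an aromatic carbon. For the measured compounds named here, no step between measured compounds guides the expectation, which rests on compound 2 and its limit of > 20000 nM alone. In this assay the expected step that the limit leaves unreadable from compound 2 to compound 3 is small, with no direction expected beyond the scatter. For compound 3 the estimated value is 30000 nM with an expected range from 8000 nM to 100000 nM here.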

Compound 3, half-maximal inhibitory concentration: > 20000 nM
Compound 3: no number, only a limit; the forecaster's own chance of this, stated with the estimate: 75%; the middle value is on the limit's open side.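

In this assay, for the compounds shown here, compound 3 gives > 20000 nM, a limit and not a number, so no step from compound 2 to compound 3 can be read. The compounds shown leave open whether 1-benzofuran-2-yl in place of furan-2-yl alters inhibition at all.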